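Trimming the hydroxycarbamoyl chain once more

This account rests on a few compounds, and the source may have more. Where it says the series, first, only, none or still open, it means among the compounds named here.

Compound 1 `CC(C)c1cc(C(=O)N(C)c2ccc(NC(=O)CCCCCCCCC(=O)NO)cc2)c(O)cc1O` and compound 2 `CC(C)c1cc(C(=O)N(C)c2ccc(NC(=O)CCCCCCCC(=O)NO)cc2)c(O)cc1O` and compound 3 `CC(C)c1cc(C(=O)N(C)c2ccc(NC(=O)CCCCCCC(=O)NO)cc2)c(O)cc1O` share one core and differ only in the length of the saturated chain ending in hydroxycarbamoyl. In a functional assay on A549 cells (Homo sapiens) for inhibition, read by sulforhodamine B assay, with a stated time of 48 h (on this read-out higher numbers stand for weaker inhibition of growth and lower numbers for stronger inhibition of growth), compound 1 gives 1080 nM while compound 2 gives 440 nM and compound 3 gives 770 nM on the same read-out. Compound 3 thus sits within the usual scatter of both others, though those two lie apart beyond it.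

Compound 4 `CC(C)c1cc(C(=O)N(C)c2ccc(NC(=O)CCCCCC(=O)NO)cc2)c(O)cc1O` trims the chain again (hydroxycarbamoyl in place of (hydroxycarbamoyl)methyl on a saturated chain carbon, five bonds along the chain from a carbonyl carbon) with hydroxycarbamoyl in place of (hydroxycarbamoyl)methyl on a saturated chain carbon, five bonds along the chain from a carbonyl carbon.

The same kind of trim gave a 2.5-fold lower number from compound 1 to compound 2 (0.39 log units; beyond the scatter) and then a 1.8-fold higher number from compound 2 to compound 3 (0.24 log units; within the scatter) in the opposite direction. Together the two amounted to a 1.4-fold lower number from compound 1 to compound 3 (0.15 log units; within the scatter) overall. Chain length shows no steady trend across these compounds, so no step beyond the scatter is expected in this assay. The estimated change is a 1.1-fold higher number from compound 3 to compound 4 (0.04 log units; within the scatter) as a best guess. Compound 4 is expected to give 850 nM with a range from 400 nM to 1800 nM as the likely span.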

Compound 4, concentration for 50% growth inhibition: 2830 nM
Compound 4: the middle estimate sits 3.3-fold (0.52 log units) below what was measured; measured number above the stated range.
By their numbers in this assay, from the lowest: compounds 2, 3 and 1 (each within the scatter of the next, the first and the last beyond it); then compound 4.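

In this assay, the same trim of the chain, with hydroxycarbamoyl in place of (hydroxycarbamoyl)methyl, now gives a 3.7-fold higher number from compound 3 to compound 4 (0.57 log units; beyond the scatter), the first rise in this series beyond the scatter. Compound 4 also stands apart from the two longer chains, with a 6.4-fold higher number from compound 2 to compound 4 (0.81 log units; beyond the scatter) and a 2.6-fold higher number from compound 1 to compound 4 (0.42 log units; beyond the scatter), so it is the weakest growth inhibitor of the four. The effect of this trim therefore depends on the chain it is applied to, and shortening at this point costs activity where earlier trims did not: the same change on two cores in this assay, a 2.5-fold lower number (0.39 log units; beyond the scatter) from compound 1 to compound 2 and a 3.7-fold higher number (0.57 log units; beyond the scatter) from compound 3 to compound 4, 9.0-fold (0.96 log units) apart, beyond the scatter of two such steps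

The compounds shown leave open whether a still shorter chain would raise the number further or whether a longer chain than that of compound 1 would raise it too. They also leave open how a carboxylic acid in place of hydroxycarbamoyl would behave on these chains.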